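Working notes: tert-butyl to benzyl on the shared core

The compounds below may be only part of what the source reports. "The series", "measured", "known", "first", "only" and "open" are said of these compounds alone.

Compound 1 (`CCOC(=O)/C=C/C1=CC[C@H]2C(C)(C)CCC[C@]2(C)[C@H]1C=O`) gives 25000 nM
Compound 2 (`CC(C)(C)OC(=O)/C=C/C1=CC[C@H]2C(C)(C)CCC[C@]2(C)[C@H]1C=O`) gives 29000 nM
Compound 3 (`CC1(C)CCC[C@]2(C)[C@@H](C=O)C(/C=C/C(=O)OCc3ccccc3)=CC[C@@H]12`) is not yet measured

In a functional assay on A549 cells (Homo sapiens) for inhibition, read by MTT assay, with a stated time of 72 h (on this read-out lower numbers stand for stronger inhibition of growth and higher numbers for weaker inhibition of growth), compound 2 gives 29000 nM and stands level with compound 1 within the scatter. The change to compound 3 is benzyl in place of tert-butyl on an oxygen next to a carbonyl group. Going by the values given here, the one measured step at this place is a 1.2-fold higher number from compound 1 to compound 2 (0.06 log units; within the scatter) and it involves no ring, so benzyl remains untested here. No step beyond the scatter is therefore expected in this assay in either direction. An estimated 1.2-fold lower number from compound 2 to compound 3 (0.08 log units; within the scatter) is what the notes expect. Compound 3 is expected at 24000 nM (estimated range 11000 nM to 50000 nM).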

Compound 3, concentration for 50% growth inhibition: 28000 nM
Estimate against measurement, compound 3: 1.2-fold (0.07 log units) below; low and high end bracket the measured number.
By their numbers in this assay, from the lowest: compounds 1, 3 and 2 (each within the scatter of the next).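

In this assay benzyl in place of tert-butyl on an oxygen next to a carbonyl group gives a 1.0-fold lower number from compound 2 to compound 3 (0.02 log units; within the scatter) and the comparison with the ethyl group gives a 1.1-fold higher number from compound 1 to compound 3 (0.05 log units; within the scatter) so a six-membered aromatic ring of carbon only at this place leaves the number within the scatter of both open-chain groups. No measurement at hand accounts for this flat result.

On these data alone, whether a carboxylic acid or an amide at this place would move the number stays open. So does the effect of any change elsewhere on the shared core.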